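Urea Aryl Trifluoromethyl Removal in the Pyrazole Series

This account rests on a few compounds, and the source may have more. Where it says the series, first, only, none or still open, it means among the compounds named here.

Compound 2 `COc1cc(Cl)cc(-c2nn(-c3cccc(NC(=O)Nc4cc(C(F)(F)F)cc(C(F)(F)F)c4)c3)cc2-c2ccncc2)c1` stands at the lower of the two numbers seen so far in a functional assay on RPMI-8226 cells (Homo sapiens) for inhibition, read by sulforhodamine B assay, with a stated time of 48 h; on this read-out higher numbers stand for weaker inhibition and lower numbers for stronger inhibition; compound 2 gives 240 nM. The nearest neighbour is compound 1 `O=C(Nc1cccc(-n2cc(-c3ccncc3)c(-c3cc(O)cc(Cl)c3)n2)c1)Nc1ccc(Cl)c(Cl)c1`, which in this assay gives 1440 nM, a gap beyond the scatter. Going by the values given here, no step between measured compounds that differ in one place is available, so the size of the next change rests on this pair alone. Compound 3 `COc1cc(Cl)cc(-c2nn(-c3cccc(NC(=O)Nc4cccc(C(F)(F)F)c4)c3)cc2-c2ccncc2)c1` differs from compound 2 by hydrogen in place of trifluoromethyl on an aromatic carbon. Among the compounds with values here, with no measured pair of this kind to lean on, a modest loss of potency in this assay is expected, a step of a 2.5-fold higher number from compound 2 to compound 3 (0.40 log units; beyond the scatter) that sits close to the usual scatter. Compound 3 is estimated at 600 nM in this assay, with a range from 250 nM to 1500 nM.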

Compound 3, half-maximal inhibitory concentration: 430 nM
Beside the measured number, compound 3's estimate is 1.4-fold (0.14 log units) above it, and the stated range covers the measured number.
By their numbers in this assay, from the lowest: compounds 2 and 3 (each within the scatter of the next); then compound 1.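

Going by these compounds alone, the first one-place step falls at this position: in this assay, hydrogen in place of trifluoromethyl on an aromatic carbon gives a 1.8-fold higher number from compound 2 to compound 3 (0.25 log units; within the scatter), so the read-out does not separate the two compounds. One of the two trifluoromethyl groups of compound 2, with its 4 heavy atoms, can therefore leave without a step beyond the scatter, while the other stays in place in compound 3. No measurement at hand gives a reason for this result.

From the compounds shown here alone, whether compound 3 would keep its standing in this assay if the remaining trifluoromethyl also gave way to hydrogen stays open. Also open is how a nitrile or an amine on the same aromatic carbon would read, since hydrogen is the only replacement shown here.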